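Swapping the aryl arm for a pyrrolidine ring

A few compounds are considered here, and "the series" means these few. Any claim that something is new, unique, unknown or untested is made for them only; others in the source may bear on it.

The shared core of compound 1 `O=C(O)c1cccc(Cc2c(-c3ccc(Cl)cc3)nn3cc(Cl)ccc23)n1` carries a 4-chlorophenyl group on an aromatic carbon. Among the compounds with values here, in a functional assay on cells for antagonist activity at prostaglandin E2 receptor EP1 subtype (Rattus norvegicus), read by fluorescence and calcium flux, with a stated time of 60 s (a higher number here means a weaker inhibitor, a lower number a stronger inhibitor), compound 1 gives 1100 nM, the highest of the two numbers measured so far. Compound 2 `CC(C)Cc1nn2cc(Cl)ccc2c1Cc1cccc(C(=O)O)n1` has an isobutyl group at that position and gives 200 nM; that change brought a 5.5-fold lower number from compound 1 to compound 2 (0.74 log units; beyond the scatter). Compound 3 `O=C(O)c1cccc(Cc2c(N3CCCC3)nn3cc(Cl)ccc23)n1` carries a pyrrolidin-1-yl group instead: pyrrolidin-1-yl in place of 4-chlorophenyl on an aromatic carbon. Within the data shown here, the one measured step bears on this: a smaller, non-aromatic group replacing the 4-chlorophenyl lowered the number by a modest amount beyond the scatter. The new group is also smaller and non-aromatic, though ring-shaped and nitrogen-linked, so a comparable but uncertain change is expected, with a 2.2-fold lower number from compound 1 to compound 3 (0.34 log units; beyond the scatter) estimated. Compound 3 is therefore expected to give about 500 nM, in a range from 150 nM to 2000 nM.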

Compound 3, half-maximal inhibitory concentration: 1800 nM
Estimate against measurement, compound 3: 3.6-fold (0.56 log units) below; measured number inside the range.
By their numbers in this assay, from the lowest: compound 2; then compounds 1 and 3 (each within the scatter of the next).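

In this assay, pyrrolidin-1-yl in place of 4-chlorophenyl gives a 1.6-fold higher number from compound 1 to compound 3 (0.21 log units; within the scatter), so this position does not separate these two rings, one aromatic and one not. Pyrrolidin-1-yl in place of isobutyl gives a 9.0-fold higher number from compound 2 to compound 3 (0.95 log units; beyond the scatter), which shows that losing the aromatic ring does not by itself bring the lower number; among these three groups, only the open-chain isobutyl stands apart. Nothing measured on these compounds explains that gap.

On these data alone, whether the lower number goes with open chains more generally remains open, and a shorter chain such as ethyl or a longer one such as pentyl would bear on that. Also unresolved is how a cyclopentyl ring, with carbon in place of the nitrogen, or an open dimethylamino group would compare at this position.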